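The compounds below may be only part of what the source reports. "The series", "measured", "known", "first", "only" and "open" are said of these compounds alone.

In an ADME assay on microsomes from liver (Rattus norvegicus) for metabolic stability, with a stated time of 10 min, tested at 0.5 uM (on this read-out lower numbers stand for a less stable compound and higher numbers for a more stable compound), three compounds that share one core have been measured: compound 1 `Cc1noc(C)c1[C@@H]1C[C@@](C)(c2ccc(F)cc2F)N=C(N)S1` gives 78%, compound 2 `Cc1noc(C(F)F)c1[C@@H]1C[C@@](C)(c2ccc(F)cc2F)N=C(N)S1` gives 67% and compound 3 `Cc1nocc1[C@@H]1C[C@@](C)(c2ccc(F)cc2F)N=C(N)S1` gives 77%. Compound 3 stands close to compound 1, with a number 1 percentage points lower from compound 1 to compound 3 (within the scatter). Its gap to the other measured compound is wider but still not a clear difference, with a number 10 percentage points higher from compound 2 to compound 3 (within the scatter).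

The next compound, compound 4 `C[C@@]1(c2ccc(F)cc2F)C[C@@H](c2cncnc2)SC(N)=N1`, has not been measured. It carries pyrimidin-5-yl in place of 3-methyl-1,2-oxazol-4-yl on a saturated ring carbon, next to the ring sulfur: pyrimidin-5-yl in place of 3-methyl-1,2-oxazol-4-yl on a saturated ring carbon.

For the measured compounds named here, no measured step makes this exchange of one whole aromatic ring for another, so the evidence is only indirect. The measured steps change just one group on an aromatic carbon. Hydrogen in place of methyl gave a number 1 percentage points lower from compound 1 to compound 3 (within the scatter), and difluoromethyl in place of methyl gave a number 11 percentage points lower from compound 1 to compound 2 (beyond the scatter), the only step beyond the scatter and a modest one. On that limited evidence, no step beyond the scatter is expected, and the estimated step is a number 3 percentage points lower from compound 3 to compound 4 (within the scatter). The larger change in structure still calls for a wide range. For compound 4 the expected value is 74%, with an estimated range from 55% to 88%.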

Compound 4, percent of the compound remaining: 95%
Beside the measured number, compound 4's estimate is 21 percentage points below it, and the stated range ends below it.
By their numbers in this assay, from the lowest: compounds 2, 3 and 1 (each within the scatter of the next, the first and the last beyond it); then compound 4.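

For the compounds shown here, exchanging the whole aromatic ring on this saturated ring carbon reaches something the earlier changes did not: in this assay, pyrimidin-5-yl in place of 3-methyl-1,2-oxazol-4-yl gives a number 18 percentage points higher from compound 3 to compound 4 (beyond the scatter), and pyrimidin-5-yl in place of 3,5-dimethyl-1,2-oxazol-4-yl gives a number 17 percentage points higher from compound 1 to compound 4 (beyond the scatter), so the number can move upward from this position, whereas the only earlier step beyond the scatter went down. The groups that leave and enter have equal counts of heavy atoms and hydrogen-bond acceptors, so these counts do not separate them, while the ring changes from five-membered to six-membered and the hetero atoms change from one nitrogen and one oxygen to two nitrogens. Nothing available here identifies what lies behind this rise.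

As far as these compounds go, it remains open whether a phenyl or pyridin-3-yl ring on the same carbon would give a number close to that of compound 4 or close to that of compound 3, which would help separate the role of ring size from that of the ring nitrogens. Also open, from the compounds shown here alone, is how a methyl group or an amine on the pyrimidine ring would shift the number.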